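Chloro to Methyl Across a Shared Core

The source may report more compounds than this note shows. Statements on the series, on what has been measured and on what is new or still open speak of the compounds shown alone.

Of the compounds shown here, three have been measured so far. Compound 1 `CC(C)(C)Cc1csc(N)c1C(=O)c1ccc(Cl)cc1` carries a neopentyl group, an amino group and a (4-chlorophenyl)carbonyl group on its core. In an assay on CHO cells for displacement of a labelled ligand from adenosine receptor A1 (Homo sapiens), read by scintillation counting, tested at 10 uM (a higher number here means more inhibition at the concentration tested (going by the name of the read-out), a lower number less inhibition), compound 1 gives 1%. Compound 2 `CC(C)(C)Cc1c(-c2ccc(Cl)cc2)sc(N)c1C(=O)c1ccc(Cl)cc1` differs from compound 1 in its core by hydrogen in place of 4-chlorophenyl on an aromatic carbon; in this assay compound 2 gives 1%. Compound 3 `Cc1ccc(-c2sc(N)c(C(=O)c3ccc(Cl)cc3)c2CC(C)(C)C)cc1` follows from compound 2 by the change (methyl in place of chloro on an aromatic carbon), and in this assay compound 3 gives 1%. That change made a step of no change at the digits printed from compound 2 to compound 3 (within the scatter), so the two values sit within the usual scatter of each other and nothing separates them.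

Compound 4 `Cc1ccc(C(=O)c2c(CC(C)(C)C)csc2N)cc1` has not yet been measured. It arises from compound 1 by methyl in place of chloro on an aromatic carbon, and the place described for this change reads the same as for the change from compound 2 to compound 3, so it is the same change, now made on the core of compound 1 rather than on that of compound 2. For compound 4 the expected step in this assay is no change at the digits printed from compound 1 to compound 4 (within the scatter), essentially none, resting on the earlier step of no change at the digits printed from compound 2 to compound 3 (within the scatter) and on compound 1 giving 1%. Compound 4 is therefore estimated to give 1%, with a range from -8% to 10%.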

Compound 4, a percentage reported as inhibition, at one concentration (the size of the read-out at that concentration, not a potency): 1%
The estimate for compound 4 equals the measured number at the digits printed; measured number inside the range.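

Methyl in place of chloro, on an aromatic carbon of a six-membered aromatic ring of carbon only and para to a large group, makes a step of no change at the digits printed from compound 1 to compound 4 (within the scatter) in this assay. Set beside the same change on the core of compound 2, this step agrees with the earlier one, so on these two cores the change carries over with no visible difference: the same change on two cores in this assay, no change at the digits printed (within the scatter) from compound 2 to compound 3 and no change at the digits printed (within the scatter) from compound 1 to compound 4, 0 percentage points apart, within the scatter of two such steps

This does not show that the change would carry over in general, since compound 1 gives 1%, compound 2 gives 1%, compound 3 gives 1% and compound 4 gives 1%, so the agreement is between two steps among compounds that all show very little inhibition, and it says nothing about a core that gives clear inhibition.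

The compounds shown leave open whether another group at that place, such as a methoxy group, a nitrile or an amine, would give a clearly higher reading. They also leave open whether a carboxylic acid or a longer chain in place of the neopentyl group would do so, and whether the step from chloro to methyl would then stay as small.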